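The compounds below may be only part of what the source reports. "The series", "measured", "known", "first", "only" and "open" are said of these compounds alone.

The compounds here share a core and differ in the chain and aromatic ether carried on the ring nitrogen. Compound 2 `COc1cccc(OCCCCCN2CCCC(COC(=O)c3ccccc3N3C(=O)CC(C)C3=O)C2)c1OC` gives 8710 nM in an in vitro functional assay on HEK ts201 cells for antagonist activity at Neuronal acetylcholine receptor; alpha4/beta2 (Homo sapiens), read by fluorescence and calcium flux; a higher number here means a weaker inhibitor, a lower number a stronger inhibitor. Compound 1 `CC1CC(=O)N(c2ccccc2C(=O)OCC2CCCN(CCCCCOc3ccccc3)C2)C1=O` gives 17000 nM in this assay, and the two sit within the usual scatter of each other, so compound 2 holds the lowest of the two numbers only nominally. Compound 3 `O=C(OCC1CCN(CCCc2ccccc2)CC1)c1ccccc1-c1ccccc1`, recorded in several entries, gives 8130 nM; 8100 nM (2 entries) in this assay, with close agreement between its entries (the several entries of compound 3 in this assay, 8130 nM; 8100 nM (2 entries)).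

Compound 4 `CC1CC(=O)N(c2ccccc2C(=O)OCC2CCCN(CCCCOc3ccccc3)C2)C1=O` differs from compound 2 by phenoxy in place of (2,3-dimethoxyphenoxy)methyl on a saturated chain carbon, four bonds along the chain from an amine nitrogen in a ring. Going by the values given here, the one measured step that bears on this is a 2.0-fold lower number from compound 1 to compound 2 (0.29 log units; within the scatter), where the two methoxy groups came in and the number fell only within the scatter; compound 4 takes them away again and at the same time swaps the longer linking chain for a shorter one, a change no measured pair covers. Given that compound 1 with a plain phenoxy gives 17000 nM, compound 4 is expected to give 15000 nM, with a likely range from 5000 nM to 45000 nM. The expected step is a 1.7-fold higher number from compound 2 to compound 4 (0.24 log units; within the scatter), a rise in the number that is not expected to exceed the scatter.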

Compound 4, half-maximal inhibitory concentration: 1700 nM
For compound 4 the middle estimate is 8.8-fold (0.95 log units) above the measured one; measured number below the stated range.
By their numbers in this assay, from the lowest: compound 4; then compounds 2 and 1 (each within the scatter of the next).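

Shortening the chain on the ring nitrogen, with phenoxy in place of phenoxymethyl and nothing else changed, gives a 10-fold lower number from compound 1 to compound 4 (1.00 log units; beyond the scatter), the first step in this assay among these compounds to lie clearly beyond the scatter. The step to the same compound from its dimethoxy relative, a 5.1-fold lower number from compound 2 to compound 4 (0.71 log units; beyond the scatter), is also beyond the scatter, but it changes the chain and removes the two methoxy groups at once, so it cannot separate their contributions. Adding those methoxy groups on the longer chain gave only a 2.0-fold lower number from compound 1 to compound 2 (0.29 log units; within the scatter), so among these three compounds chain length counts for more than the methoxy groups, and repeat entries in this assay agree closely enough for a step of this size to be read with some confidence: the several entries of compound 3 in this assay, 8130 nM; 8100 nM (2 entries)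

As far as these compounds go, whether a still shorter chain would lower the number further, or whether the fall stops at this length, remains open. Also open, from the compounds shown here alone, is what the 2,3-dimethoxyphenyl group, or a simpler ring substituent such as a single methoxy or a fluorine, would do on the shorter chain of compound 4.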